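The source may report more compounds than this note shows. Statements on the series, on what has been measured and on what is new or still open speak of the compounds shown alone.

Compound 2 `COc1ccc(N(C(=O)CN2C=CN(c3ccccc3)C(=O)C(Cc3n[nH]c4ccccc34)C2=O)C(C)C)cc1` is the reference point. In a functional assay on CHO cells for agonist activity at Melanocortin receptor 4 (Homo sapiens), read by a luciferase reporter, with a stated time of 4 h (on this read-out lower numbers stand for an effect already at smaller amounts and higher numbers for an effect only at larger amounts of compound), compound 2 gives 708 nM, the highest of the two numbers in hand. Compound 3 `O=C1C(Cc2n[nH]c3ccccc23)C(=O)N(c2ccccc2)C=CN1CC(=O)N1CCCCc2ccccc21` gives 324 nM, and the step of a 2.2-fold lower number from compound 2 to compound 3 (0.34 log units; beyond the scatter) arises from an exchange of the amide substituent on the carbonyl carbon. Compound 1 `CCn1nc(CC2(OC)C(=O)N(CC(=O)N(c3ccc(OC)cc3)C(C)C)C=CN(c3ccccc3)C2=O)c2ccccc21` is recorded in this assay as 31600 nM; > 30000 nM (2 entries), several entries taken together. Compound 4 `COc1ccc(N(C(=O)CN2C=CN(c3ccccc3)C(=O)C(Cc3n[nH]c4ccccc34)(OC)C2=O)C(C)C)cc1` differs from compound 2 by methoxy in place of hydrogen on a saturated ring carbon. Among the measured compounds shown here, no measured step isolates this change: the step from compound 2 to compound 3 alters a different part of the molecule and is modest. For the measured compounds named here, compound 1 also carries a methoxy on that ring carbon, but it differs from compound 2 in a second place as well, so its entries show only that a methoxy-bearing analogue of this core sat at the weak end. Compound 4 is therefore expected to be weaker than compound 2, with a step estimated at a 17-fold higher number from compound 2 to compound 4 (1.23 log units; beyond the scatter). For compound 4 the estimate is 12000 nM, within 3000 nM to 50000 nM.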

Compound 4, half-maximal effective concentration: 166 nM
For compound 4 the middle estimate is 72-fold (1.86 log units) above the measured one; measured number below the stated range.
By their numbers in this assay, from the lowest: compounds 4 and 3 (each within the scatter of the next); then compound 2.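

In this assay, methoxy in place of hydrogen on a saturated ring carbon goes with a 4.3-fold lower number from compound 2 to compound 4 (0.63 log units; beyond the scatter), so this position, two ring bonds from the ring nitrogen, takes the group without any loss of effect. Among the compounds shown here, until now the only compound with a methoxy there sat at the weak end, and compound 4 shows that the methoxy alone does not bring that weakness with it. Compound 1, which differs from compound 4 in one other place, has entries that include a limit of the assay: the several entries of compound 1 in this assay, 31600 nM; > 30000 nM (2 entries).

The compounds shown leave open whether this ring carbon would accept other groups, such as a hydroxyl, an ethoxy or an amine, in the same way. They also leave open whether the methoxy and the amide substituent of compound 3 would add up in one molecule.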